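Trimming one methoxy from a diamino-quinoxaline growth inhibitor

The source may hold more compounds than are shown below. What is called first, only, known or untested is meant among the compounds shown, and "the series" means these compounds.

Three compounds sharing one core were tested in a functional assay on HOP-62 cells (Homo sapiens) for inhibition, read by sulforhodamine B assay, with a stated time of 48 h; on this read-out higher numbers stand for weaker inhibition of growth and lower numbers for stronger inhibition of growth. Compound 1 `Nc1cc(N)c2nc(-c3ccccc3)c(Oc3ccc(Cl)c(Cl)c3)nc2c1` gives 17000 nM; compound 2 `COc1ccc(CNc2nc3cc(N)cc(N)c3nc2-c2ccccc2)cc1OC` gives 18200 nM; compound 3 `COc1cc(CNc2nc3cc(N)cc(N)c3nc2-c2ccccc2)cc(OC)c1OC` gives 17000 nM. Compound 2 has the highest of these numbers, yet its gaps to compound 1 and compound 3 both lie within the scatter. Compound 4 `COc1ccc(CNc2nc3cc(N)cc(N)c3nc2-c2ccccc2)cc1` differs from compound 2 by hydrogen in place of methoxy on an aromatic carbon, that is, 3,4-dimethoxyphenyl becoming 4-methoxyphenyl. For the measured compounds named here, the only comparable step runs the other way, adding a methoxy: a 1.1-fold lower number from compound 2 to compound 3 (0.03 log units; within the scatter). Removing one is therefore expected to move this assay by no more than the scatter, a 1.0-fold lower number from compound 2 to compound 4 (0.00 log units; within the scatter). Compound 4 is thus estimated at 18000 nM, within a range from 9000 nM to 36000 nM.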

Compound 4, concentration for 50% growth inhibition: 17400 nM
For compound 4 the middle estimate is 1.0-fold (0.01 log units) above the measured one, and the stated range covers the measured number.
By their numbers in this assay, from the lowest: compounds 1, 3, 4 and 2 (each within the scatter of the next).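

In this assay, hydrogen in place of methoxy on this aromatic carbon, which turns 3,4-dimethoxyphenyl into 4-methoxyphenyl, gives (a 1.0-fold lower number from compound 2 to compound 4 (0.02 log units; within the scatter)). Removing a methoxy here therefore leaves the number as flat as adding one elsewhere on the same ring did (a 1.1-fold lower number from compound 2 to compound 3 (0.03 log units; within the scatter)), so this position has now been seen with and without its methoxy, with no readable change. No evidence is available on why this position makes so little difference.

Going by these compounds, whether an amine or a carboxylic acid on this carbon would also stay within the scatter remains open. So does the effect of replacing the remaining methoxy of compound 4 with hydrogen.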